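A methoxy removed: from compound 3 to compound 4

A few compounds are considered here, and "the series" means these few. Any claim that something is new, unique, unknown or untested is made for them only; others in the source may bear on it.

Compound 1 `COc1ccc(C(=O)c2cc(OC)c(OC)c(OC)c2)cc1N`: 60 nM
Compound 2 `COc1cccc(/C=C/C(=O)Nc2cc(OC)c(OC)c(OC)c2)c1`: 12300 nM
Compound 3 `COc1ccc(C(=O)c2cc(OC)c(OC)c(OC)c2)cc1NC(=O)/C=C/c1ccc(OC)c(OC)c1`: 7800 nM

All three were tested in a functional assay on HeLa cells (Homo sapiens) for cytotoxicity, read by MTT assay, with a stated time of 72 h; a lower number here means a stronger inhibitor, a higher number a weaker inhibitor. Among them compound 3 has the second highest number; its value sits close to that of compound 2, a gap within the scatter, while compound 1 lies far lower, a gap well beyond it. Compound 4 `COc1cccc(/C=C/C(=O)Nc2cc(C(=O)c3cc(OC)c(OC)c(OC)c3)ccc2OC)c1` has not yet been measured. It differs from compound 3 in one place: hydrogen in place of methoxy on an aromatic carbon, so that 3,4-dimethoxyphenyl becomes 3-methoxyphenyl. Within the data shown here, no measured pair shows this change by itself. Compound 2 also carries a 2-(3-methoxyphenyl)ethenyl group and gives 12300 nM, a number near that of compound 3. For compound 4 a step of about a 1.2-fold higher number from compound 3 to compound 4 (0.06 log units; within the scatter) is expected, not beyond the scatter. Compound 4 is estimated at 9000 nM, with a range from 3000 nM to 30000 nM.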

Compound 4, half-maximal inhibitory concentration: 3100 nM
Compound 4: the middle estimate sits 2.9-fold (0.46 log units) above what was measured; the range from low to high includes it.
By their numbers in this assay, from the lowest: compound 1; then compound 4; then compounds 3 and 2 (each within the scatter of the next).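

In this assay, replacing the methoxy with hydrogen, so that 3,4-dimethoxyphenyl becomes 3-methoxyphenyl, gives a 2.5-fold lower number from compound 3 to compound 4 (0.40 log units; beyond the scatter) in a modest but real gain. Among these compounds, this is the first reading of this change, and it shows that this methoxy, ortho to the remaining methoxy group, is not required for the activity of compound 3. No measurement shown accounts for the step.

The compounds shown leave open how a hydroxy group or a fluorine atom would read at this place. They also leave open whether the same change gives a similar step on another core.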